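The source may report more compounds than this note shows. Statements on the series, on what has been measured and on what is new or still open speak of the compounds shown alone.

Measured compounds in an assay on CHO cells for displacement of a labelled ligand from melanin-concentrating hormone receptor 1 (Homo sapiens), read by scintillation counting, with a stated time of 1 h; a higher number here means a weaker inhibitor, a lower number a stronger inhibitor:
compound 1 `CCc1nc2ccc(-n3ccc(OCc4ccc(F)cc4)cc3=O)cc2n1C`, compound 1 gives 48 nM
compound 2 `Cn1c(C2CC2)nc2ccc(-n3ccc(OCc4ccc(F)cc4)cc3=O)cc21`, compound 2 gives 40 nM
compound 3 `Cn1c(CC(C)(C)C)nc2ccc(-n3ccc(OCc4ccc(F)cc4)cc3=O)cc21`, compound 3 gives > 1000 nM, which is a limit of this assay and not a number the limit of > 1000 nM in this assay, at which 1 of the 3 values shown sits.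

Compound 2 gives the lowest of the two numbers shown, with compound 1 nearest at a 1.2-fold lower number from compound 1 to compound 2 (0.08 log units; within the scatter), so the two cannot be told apart. The exchange from compound 2 to compound 3 is large: an at least 25-fold higher number from compound 2 to compound 3 (1.39 log units; beyond the scatter). Likewise from compound 1 to compound 3: an at least 20-fold higher number from compound 1 to compound 3 (1.31 log units; beyond the scatter). Both of these changes sit on the core, not on the benzyloxy side.

Compound 4 `Cn1c(C2CC2)nc2ccc(-n3ccc(OCc4ccccc4Cl)cc3=O)cc21` differs from compound 2 in a different place: 2-chlorophenyl in place of 4-fluorophenyl on a saturated chain carbon bound to an oxygen on an aromatic ring. For the measured compounds named here, none of the measured steps touches this part of the molecule, so there is nothing here to set the direction or size of the change. With no contrary evidence, the expected step from compound 2 to compound 4 is a 1.3-fold higher number from compound 2 to compound 4 (0.10 log units; within the scatter), that is, none beyond the scatter, though the range must be kept wide. Compound 4 is therefore estimated at 50 nM in this assay, expected between 15 nM and 200 nM.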

Compound 4, half-maximal inhibitory concentration: 160 nM
The estimate for compound 4 lay 3.2-fold (0.51 log units) below the measured number; low and high end bracket the measured number.
By their numbers in this assay, from the lowest: compounds 2 and 1 (each within the scatter of the next); then compound 4. At a limit, above all of these: compound 3.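

In this assay, the aryl group of the benzyloxy side proves able to move the number on its own: 2-chlorophenyl in place of 4-fluorophenyl gives a 4.0-fold higher number from compound 2 to compound 4 (0.60 log units; beyond the scatter). For the compounds shown here, the earlier steps beyond the scatter all lay on the core, so this is the only reading at this position; it is modest, and compound 4 still gives a number rather than a limit. Nothing available here bears on the reason for this step.

The exchange alters both the halogen and its place on the ring, and the compounds shown cannot separate the two; the 4-chlorophenyl and 2-fluorophenyl groups would do so. As far as these compounds go, how unsubstituted phenyl, or a longer chain on the oxygen, would read at this position also stays open.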